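Ring-nitrogen alkyl and core swap in an imidazoline series

The compounds below may be only part of what the source reports. "The series", "measured", "known", "first", "only" and "open" are said of these compounds alone.

Compound 1 `Cn1cc(-c2ccccc2NCC2=NCCN2)cn1` carries a 1-methyl-1H-pyrazol-4-yl group on the shared core and in an in vitro functional assay on cells (Fibroblast) for agonist activity at Alpha-1A adrenergic receptor (Homo sapiens) (on this read-out higher numbers stand for an effect only at larger amounts of compound and lower numbers for an effect already at smaller amounts), gives 398 nM. Compound 3 `Cn1cccc1-c1ccccc1NCC1=NCCN1` replaces that group by 1-methyl-1H-pyrrol-2-yl; the counted difference is 1-methyl-1H-pyrrol-2-yl in place of 1-methyl-1H-pyrazol-4-yl on an aromatic carbon. In this assay, going by the values given here, compound 3 gives 20 nM, and the step is a 20-fold lower number from compound 1 to compound 3 (1.30 log units; beyond the scatter), so compound 3 sits at the low end of the two numbers known here.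

Compound 2 `CCn1cc(-c2ccccc2NCC2=NCCN2)cn1` differs from compound 1 by methyl in place of hydrogen on a saturated chain carbon bound to an aromatic nitrogen. For compound 2 the result in this assay is only a limit, < 100000 nM, and that is the limit of < 100000 nM in this assay, at which 1 of the 3 values shown sits. The step is therefore a step that the limit leaves unreadable from compound 1 to compound 2: its size cannot be read.

Compound 4 `CCn1cccc1-c1ccccc1NCC1=NCCN1` is the matching partner of compound 3, differing by methyl in place of hydrogen on a saturated chain carbon bound to an aromatic nitrogen. The two differences share the same place word for word, so this is the same change as from compound 1 to compound 2. Among the compounds with values here, the only measured example of it ends in a limit, which gives no size to carry over. What remains is that compound 3 itself gives 20 nM, a number that leaves room for a loss. Compound 4 is expected to give about 60 nM in this assay, between 12 nM and 600 nM, which means an expected step of a 3.0-fold higher number from compound 3 to compound 4 (0.48 log units; beyond the scatter); the wide range reflects that the unreadable step between compound 1 and compound 2 gives no anchor.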

Compound 4, half-maximal effective concentration: 2.51 nM
The estimate for compound 4 lay 24-fold (1.38 log units) above the measured number; measured number outside the range, below it.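

Notes on carrying the change: in this assay, methyl in place of hydrogen on a saturated chain carbon bound to an aromatic nitrogen (methyl to ethyl) gives an 8.0-fold lower number from compound 3 to compound 4 (0.90 log units; beyond the scatter), so on the core bearing 1-methyl-1H-pyrrol-2-yl the change goes with a lower number, beyond the scatter. The same change on the core bearing 1-methyl-1H-pyrazol-4-yl cannot be read, since compound 2 gives only a limit and not a number: the limit of < 100000 nM in this assay, at which 1 of the 4 values shown sits. This leaves one readable example of the change, which shows its size on a single core and does not show that this size or even its direction carries over to the other core, so no transfer between the two cores can be claimed.

The compounds shown leave open how a chain longer than ethyl, such as propyl or butyl, would read in this assay on either core, and whether the lower number continues or reverses along such a series. Also open, as far as these compounds go, is how a chain ending in an amine or a carboxylic acid, in that same place, would compare with the methyl and ethyl groups.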